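Replacing the sulfonic acid of compound 2 with a pyridinyl sulfonamide

The source may hold more compounds than are shown below. What is called first, only, known or untested is meant among the compounds shown, and "the series" means these compounds.

The series rests on a shared core carrying a brominated naphthylmethyl group and a thioether-linked chain. Compound 1 `Oc1c(Br)cc(CSc2nnc(Br)n2Cc2ccc(Br)c3ccccc23)cc1Br` bears a 3,5-dibromo-4-hydroxyphenyl group on that chain carbon, and in an assay on HEK293 cells for inhibition of solute carrier family 22 member 12 (Homo sapiens) (on this read-out lower numbers stand for stronger inhibition and higher numbers for weaker inhibition), compound 1 gives 119000 nM. Compound 2 `O=S(=O)(O)CSc1nnc(Br)n1Cc1ccc(Br)c2ccccc12` carries a sulfo group there instead, and in this assay compound 2 gives 14400 nM. Within the data shown here, this step, an 8.3-fold lower number from compound 1 to compound 2 (0.92 log units; beyond the scatter), leaves compound 2 with the lowest of the two numbers so far, with compound 1 as its only neighbour.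

Compound 3 `O=S(=O)(CSc1nnc(Br)n1Cc1ccc(Br)c2ccccc12)Nc1cccnc1` changes compound 2 at the sulfonyl sulfur: (pyridin-3-yl)amino in place of hydroxy on a sulfonyl sulfur. Among the measured compounds shown here, no measured pair covers this change; the only measured step, from compound 1 to compound 2, concerns a different substituent at the same chain carbon and shows that this position responds to substitution. For the measured compounds named here, with no directly comparable step, the expected change in this assay is an uncertain one, leaning toward a somewhat higher number, a 2.1-fold higher number from compound 2 to compound 3 (0.32 log units; beyond the scatter). Compound 3 is therefore estimated at 30000 nM, within a range from 8000 nM to 120000 nM.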

Compound 3, half-maximal inhibitory concentration: 32 nM
Compound 3: middle estimate off by 940-fold (2.97 log units), on the high side; the whole stated range lies above it.
By their numbers in this assay, from the lowest: compound 3; then compound 2; then compound 1.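

In this assay, the sulfonyl sulfur proves far more sensitive than the earlier change at the chain carbon had shown: the replacement of hydroxy by (pyridin-3-yl)amino gives a 450-fold lower number from compound 2 to compound 3 (2.65 log units; beyond the scatter) and so outweighs by a wide margin the earlier step, an 8.3-fold lower number from compound 1 to compound 2 (0.92 log units; beyond the scatter) on exchanging the aryl group for sulfo. Taken as one change at the chain carbon, (pyridin-3-yl)sulfamoyl in place of 3,5-dibromo-4-hydroxyphenyl gives a 3700-fold lower number from compound 1 to compound 3 (3.57 log units; beyond the scatter) and places the whole span of the series on this one position, with the sulfo group only part of the way along it. No measurement at hand explains why the entering group has so large an effect.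

The compounds shown leave open which part of the (pyridin-3-yl)amino group carries the step, since the ring and its nitrogen enter together with the nitrogen on the sulfonyl sulfur. A plain amino group on that sulfur would speak to the role of the ring, and a phenylamino group would speak to the role of the ring nitrogen.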